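This account rests on a few compounds, and the source may have more. Where it says the series, first, only, none or still open, it means among the compounds named here.

Working notes on the series.

Three compounds of this set have been run in a functional assay on PC-3 cells (Homo sapiens) for inhibition, with a stated time of 72 h; a higher number here means a weaker inhibitor, a lower number a stronger inhibitor. Compound 1 `COc1cc(NC(=O)Nc2nc(Nc3cc(OC)cc(OC)c3)cc(Sc3c[nH]c4ccccc34)n2)cc(OC)c1` gives 11600 nM; compound 2 `COc1ccc(NC(=O)Nc2nc(Nc3cc(OC)cc(OC)c3)cc(Sc3c[nH]c4ccccc34)n2)cc1` gives 15100 nM; compound 3 `Cc1ccc(C)c(NC(=O)Nc2nc(Sc3c[nH]c4ccccc34)cc(N3CCN(Cc4ccccc4)CC3)n2)c1` gives 17300 nM. Compound 2 sits second highest of the three numbers, with compound 3 nearest and compound 1 furthest, and both of those gaps are within the scatter, so no order among the three can be read from these values. For the measured compounds named here, the one single-point step measured so far, a 1.3-fold higher number from compound 1 to compound 2 (0.11 log units; within the scatter), concerns the group on the amide-type nitrogen and not the position changed here.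

Compound 4 `COc1ccc(NC(=O)Nc2nc(Sc3c[nH]c4ccccc34)cc(N3CCN(c4ccccn4)CC3)n2)cc1` arises from compound 2 by the change (4-(pyridin-2-yl)piperazin-1-yl in place of (3,5-dimethoxyphenyl)amino on an aromatic carbon). Compound 3 carries a piperazine-type group at the same aromatic carbon, though with a different group on the urea, and its value and that of compound 2 lie within the scatter of each other. Going by the values given here, no measured step bears directly on the exchange, and the values shown give no sign that the three compounds separate at all in this assay. The expectation is therefore a step of about a 1.1-fold higher number from compound 2 to compound 4 (0.03 log units; within the scatter), within the scatter. Compound 4 is estimated at 16000 nM, with a range from 7000 nM to 36000 nM.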

Compound 4, half-maximal inhibitory concentration: 33400 nM
Beside the measured number, compound 4's estimate is 2.1-fold (0.32 log units) below it; the range from low to high includes it.
By their numbers in this assay, from the lowest: compounds 1, 2, 3 and 4 (each within the scatter of the next, the first and the last beyond it).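

In this assay, for the compounds shown here, replacing (3,5-dimethoxyphenyl)amino with 4-(pyridin-2-yl)piperazin-1-yl on the aromatic carbon next to the ring nitrogen gives a 2.2-fold higher number from compound 2 to compound 4 (0.34 log units; beyond the scatter) and is the first single-point step in this set to lie beyond the scatter, though only modestly. Going by these compounds alone, this position therefore responds to a change of group, which the earlier compounds could not show, as their one step concerned the group on the amide-type nitrogen and stayed within the scatter. The exchange alters several things at once, removing the hydrogen-bond donor and the carbon-only aromatic ring and introducing a piperazine ring and a pyridine ring, and nothing available accounts for the step.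

The compounds shown leave open whether the step belongs to the piperazine ring or to its pyridin-2-yl group, a question that an unsubstituted piperazine, a morpholine or a dimethylamino group at the same carbon would address with the 4-methoxyphenyl urea held fixed. Going by these compounds, it also remains open whether the step of this exchange carries over when the urea bears the 3,5-dimethoxyphenyl group of compound 1.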